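The source may hold more compounds than are shown below. What is called first, only, known or untested is meant among the compounds shown, and "the series" means these compounds.

In a functional assay on SK-OV-3 cells (Homo sapiens) for inhibition, read by CCK-8 assay, with a stated time of 70 h (on this read-out lower numbers stand for stronger inhibition and higher numbers for weaker inhibition), compound 1 (`c1ccc(COc2ccc(OCCOCCNC3CCCC3)cc2)cc1`) gives 24800 nM. Compound 2 (`COc1ccc(COc2ccc(OCCOCCNC3CCCC3)cc2)cc1`) gives 15700 nM, and compound 3 (`Clc1ccc(COc2ccc(OCCOCCNC3CCCC3)cc2)cc1`) gives 7670 nM. Compound 1 thus stands at the high-number end of this small set, though it cannot be separated from compound 2: the measured difference is a 1.6-fold lower number from compound 1 to compound 2 (0.20 log units; within the scatter). Only compound 3 lies clearly lower, with a 3.2-fold lower number from compound 1 to compound 3 (0.51 log units; beyond the scatter).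

Compound 4 (`c1ccc(COc2ccc(OCCOCCNC3CCC3)cc2)cc1`) keeps the core of compound 1 but carries cyclobutyl in place of cyclopentyl on an amine nitrogen.

For the measured compounds named here, none of the measured steps touches that amine group. All three change a group on an aromatic carbon, and the remaining one is a 2.0-fold lower number from compound 2 to compound 3 (0.31 log units; beyond the scatter). Going by the values given here, they show only that changes elsewhere have been small, at most modest, and they say nothing direct about ring size at the amine. No change beyond the scatter is therefore expected in this assay. The expected step is a 1.0-fold higher number from compound 1 to compound 4 (0.02 log units; within the scatter). Compound 4 is estimated at 26000 nM, with an expected range of 12000 nM to 55000 nM.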

Compound 4, half-maximal inhibitory concentration: 25000 nM
For compound 4 the middle estimate is 1.0-fold (0.02 log units) above the measured one; the range from low to high includes it.
By their numbers in this assay, from the lowest: compound 3; then compounds 2, 1 and 4 (each within the scatter of the next).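

In this assay, the only change shown at the amine nitrogen gives a 1.0-fold higher number from compound 1 to compound 4 (0.00 log units; within the scatter), so the four-membered ring serves here as well as the five-membered one. The earlier compounds shown here varied only a group on an aromatic carbon, where chloro in place of hydrogen moved the number beyond the scatter; this pair adds that the cyclopentyl ring can be reduced to cyclobutyl on the amine nitrogen with no change beyond the scatter. Nothing available gives a reason for this result.

Going by these compounds, whether a larger ring such as cyclohexyl, or an open chain such as isopropyl, would also leave the number in place remains open. So does whether chloro on the aromatic carbon, as in compound 3, would keep its lower number when combined with cyclobutyl on the amine nitrogen.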